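The source may hold more compounds than are shown below. What is called first, only, known or untested is meant among the compounds shown, and "the series" means these compounds.

In an ADME assay on a cell-free system (plasma, Rattus norvegicus) for protein binding (a lower number here means a smaller unbound share, a higher number a larger unbound share of the compound), compound 1 (`N#Cc1ccc(O[C@H]2CN(S(=O)(=O)c3ccc(C(F)(F)F)cc3)C[C@@]2(O)CO)cc1F`) gives 0.033. Among the compounds with values here, the only other measured compound, compound 2 (`N#Cc1ccc(O[C@H]2CN(S(=O)(=O)c3ccc(Cl)cc3Cl)C[C@@]2(O)CN)cc1F`), gives 0.036, and these two numbers lie within the scatter of each other. Both compounds therefore leave only a small share unbound. Compound 3 (`N#Cc1ccc(O[C@H]2CN(S(=O)(=O)c3ccccc3C#N)C[C@@]2(O)CO)cc1F`) keeps the core of compound 1 and carries 2-cyanophenyl in place of 4-(trifluoromethyl)phenyl on a sulfonyl sulfur. Within the data shown here, compound 1 and compound 2 differ in more than one place, so no measured pair isolates a change at this position. The expectation rests on the structural change alone and remains loose. A moderate rise in this assay, somewhat beyond the scatter, is expected, with an estimated 3.0-fold higher number from compound 1 to compound 3 (0.48 log units; beyond the scatter). The estimated value for compound 3 is 0.1, with an expected range from 0.05 to 0.2.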

Compound 3, unbound fraction: 0.197
For compound 3 the middle estimate is 2.0-fold (0.29 log units) below the measured one; measured number inside the range.
By their numbers in this assay, from the lowest: compounds 1 and 2 (each within the scatter of the next); then compound 3.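

Changing the group on the sulfonyl sulfur clearly matters: in this assay, 2-cyanophenyl in place of 4-(trifluoromethyl)phenyl gives a 6.0-fold higher number from compound 1 to compound 3 (0.78 log units; beyond the scatter) while the rest of compound 1 stays the same. Within the data shown here, this is the first view of this position alone, as compound 1 and compound 2 differ in more than one place and could not separate its contribution. No measurement shown here accounts for the larger unbound share.

On these data alone, the swap replaces one whole group with another, so it remains open whether the step follows the arrival of the nitrile or the departure of the trifluoromethyl. A plain phenyl on the sulfonyl sulfur would help to separate these two, and an amine or a carboxylic acid on that ring would test how far the unbound share can move.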